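The compounds below may be only part of what the source reports. "The series", "measured", "known", "first", "only" and "open" are said of these compounds alone.

Measured so far, in a functional assay on CHO cells for antagonist activity at adenosine receptor A2b (Homo sapiens), read by 33P incorporation, with a stated time of 20 min; on this read-out higher numbers stand for weaker inhibition and lower numbers for stronger inhibition:
compound 1 `Cn1c(-c2ccc(O)cc2)nc2c(NC3CCCC3)ncnc21`: 17800 nM
compound 2 `CCn1c(-c2ccccc2)nc2c(NC3CCCCC3)ncnc21`: 9020 nM

Compound 1 holds the highest of the two numbers in this assay; the nearest is compound 2, whose value lies within the usual scatter of compound 1, so no order between the two can be read from them. Compound 3 `COc1ccc(-c2nc3c(NC4CCCC4)ncnc3n2C)cc1` is not yet measured. It differs from compound 1 in one place: methyl in place of hydrogen on an oxygen on an aromatic ring. Among the compounds with values here, no step between two measured compounds bears on this change of hydroxy to methoxy, so the expectation rests on compound 1 alone. The substitution is small in what leaves and enters, and no step beyond the scatter is expected in either direction in this assay. Compound 3 is therefore expected near 15000 nM, within a range of 5000 nM to 45000 nM. The expected step is thus a 1.2-fold lower number from compound 1 to compound 3 (0.07 log units; within the scatter).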

Compound 3, inhibition constant: > 30000 nM
Compound 3 gave a limit, no number; the forecaster's own chance of this, stated with the estimate: 15%; middle value at least 2.0-fold (0.30 log units) away from the limit.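

In this assay, within the data shown here, the change of 4-hydroxyphenyl to 4-methoxyphenyl gives the first single-place comparison, and it reads as an at least 1.6-fold higher number from compound 1 to compound 3 (0.22 log units; that floor lies within the scatter). Compound 3 is read only as a limit of the assay: the limit of > 30000 nM in this assay, at which 1 of the 3 values shown sits. Methyl on this oxygen therefore shows no stronger inhibition for compound 3 than for compound 1, and how far the step extends past its floor cannot be told.

Going by these compounds, compound 2 differs from compound 1 in more than one place, so it does not show what the hydroxy group alone contributes, and whether any oxygen is needed on this aromatic ring stays open. An amine in place of the hydroxy group, or a longer chain on the oxygen such as ethyl, would test this position further.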